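The source may hold more compounds than are shown below. What is called first, only, known or untested is meant among the compounds shown, and "the series" means these compounds.

Measured compounds in this series:

Compound 1, `COc1ccc(/C=C/S(=O)(=O)Cc2ccc(OC)cc2)cc1`: > 20000 nM (a limit of the assay)
Compound 2, `COc1ccc(CS(=O)(=O)/C=C/c2ccc(F)cc2)cc1`: 1250 nM
Compound 3, `COc1ccc(CS(=O)(=O)/C=C/c2ccc([N+](=O)[O-])cc2)cc1`: 7500 nM

In a functional assay on DU-145 cells (Homo sapiens) for antiproliferative activity, read by trypan blue exclusion (on this read-out lower numbers stand for stronger inhibition and higher numbers for weaker inhibition), compound 1 gives > 20000 nM, which is a limit of the assay and not a number, so compound 1 stands only at that limit (the limit of > 20000 nM in this assay, at which 1 of the 3 values shown sits). In the same assay compound 2 gives 1250 nM and compound 3 gives 7500 nM. The two steps away from compound 1 both replace its methoxy: an at least 16-fold lower number from compound 1 to compound 2 (1.20 log units; beyond the scatter) and an at least 2.6-fold lower number from compound 1 to compound 3 (0.42 log units; beyond the scatter); between them, a 6.0-fold higher number from compound 2 to compound 3 (0.78 log units; beyond the scatter).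

Compound 4, `COc1ccc(CS(=O)(=O)/C=C/c2ccc(OC)c(OC)c2)cc1`, differs from compound 1 by methoxy in place of hydrogen on an aromatic carbon. For the measured compounds named here, no measured step adds a group; the measured steps only exchange the methoxy, and each exchange lowered the number. The step to compound 4 keeps the methoxy of compound 1 and adds a second one, so the measured steps bear on it only weakly. Compound 1 sits at the limit, and with a second methoxy the number is expected to stay near it: an at least 1.3-fold lower number from compound 1 to compound 4 (0.12 log units; that floor lies within the scatter) is the expected step, within or only slightly beyond the scatter. Compound 4 is estimated at 15000 nM, with a range from 4000 nM to 40000 nM.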

Compound 4, half-maximal inhibitory concentration: > 20000 nM
Compound 4 gave a limit, no number; the forecaster's own chance of this, stated with the estimate: 45%; at least 1.3-fold (0.12 log units) between middle value and limit.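

In this assay compound 4 gives > 20000 nM, a limit of the assay and not a number, and compound 1 stands at the same limit, so the step between them cannot be read: the limit of > 20000 nM in this assay, at which 2 of the 4 values shown sit.

The compounds shown leave open whether methoxy in place of hydrogen on an aromatic carbon changes the read-out at all.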